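The source may report more compounds than this note shows. Statements on the series, on what has been measured and on what is new or still open speak of the compounds shown alone.

Measured compounds in a physicochemical assay for solubility, read by nephelometry, in phosphate buffer, measured as kinetic solubility, at pH 6.5; on this read-out lower numbers stand for lower solubility and higher numbers for higher solubility:

Compound 1 `COc1ccc(-c2cc(-c3ccc(S(=O)(=O)N(C)C)cc3)cnc2N)cn1` gives 6.3 ug/mL.
Compound 2 `COc1ccc(-c2cc(-c3ccc(S(N)(=O)=O)cc3)cnc2N)cn1` gives 12.5 ug/mL.
Compound 3 `COc1ccc(-c2cc(-c3ccc(S(C)(=O)=O)c(F)c3)cnc2N)cn1` gives 6.3 ug/mL.

All three share one core and differ only in the group on the outer benzene ring. Compound 2 carries the highest of the three numbers, yet its gaps to compound 1 and to compound 3 are each within the usual scatter of repeated measurements, so on this read-out the three cannot be told apart with confidence.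

Compound 4 `COc1ccc(-c2cc(-c3ccc(C(N)=O)cc3)cnc2N)cn1` is the next compound in this series. Its change from compound 2 is carbamoyl in place of sulfamoyl on an aromatic carbon. Within the data shown here, only one measured step speaks to this part of the molecule: a 2.0-fold higher number from compound 1 to compound 2 (0.30 log units; within the scatter), which swapped the substituents on the sulfonyl sulfur but kept the sulfonyl itself. Among the measured compounds shown here, no measured step replaces a sulfonyl with a carbonyl, so the evidence is indirect. Given that the one related step stayed within the scatter, compound 4 is expected to land close to compound 2, with a step of a 1.3-fold lower number from compound 2 to compound 4 (0.10 log units; within the scatter) that is not expected to exceed the scatter. Compound 4 is therefore estimated at 10 ug/mL, with a range from 4 ug/mL to 25 ug/mL.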

Compound 4, solubility: 12.5 ug/mL
Compound 4: the middle estimate sits 1.3-fold (0.10 log units) below what was measured; the range from low to high includes it.
By their numbers in this assay, from the lowest: compounds 1, 3, 2 and 4 (each within the scatter of the next).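

In this assay, among these compounds, the step of no change at the digits printed from compound 2 to compound 4 (within the scatter) gives the first direct reading of a carbonyl-based group in place of a sulfonyl-based group at this position on the outer benzene ring. The step of a 2.0-fold higher number from compound 1 to compound 4 (0.30 log units; within the scatter) also stays within the scatter, so sulfamoyl, dimethylsulfamoyl and carbamoyl, para to a large group, cannot be told apart on this read-out. Nothing available explains this lack of separation.

Going by these compounds, it remains open whether a carboxylic acid or an amine on this same aromatic carbon would produce a step beyond the scatter. Also unresolved is whether dimethylcarbamoyl would read like carbamoyl, which would show whether substituents on the amide nitrogen matter any more than those on the sulfonyl sulfur.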